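A few compounds are considered here, and "the series" means these few. Any claim that something is new, unique, unknown or untested is made for them only; others in the source may bear on it.

Measured compounds:
compound 1 `Cc1ccc(/C=C2/N=C(c3ccccc3)N(C(=O)COc3ccccc3)NC2=O)cc1` — 300 mg/kg
compound 2 `Cc1ccc(/C=C2/N=C(c3ccccc3)N(C(=O)c3ccc(Cl)cc3)NC2=O)cc1` — 100 mg/kg
compound 3 `Cc1ccc(C(=O)N2NC(=O)/C(=C\c3ccc(O)cc3)N=C2c2ccccc2)cc1` — 100 mg/kg

In a functional assay on the whole organism (strain albino) with Mus musculus as the target, with a stated time of 0.5 h (on this read-out lower numbers stand for an effect already at smaller amounts and higher numbers for an effect only at larger amounts of compound), compound 3 stands level with compound 2 at the digits reported, and the two are together the lowest of the three numbers; compound 1 lies furthest from compound 3. For the measured compounds named here, the one measured step, a 3.0-fold lower number from compound 1 to compound 2 (0.48 log units; beyond the scatter), concerns a change on a carbonyl carbon and does not touch the aromatic ring that is altered here. Compound 4 `COc1ccc(/C=C2/N=C(c3ccccc3)N(C(=O)c3ccc(C)cc3)NC2=O)cc1` differs from compound 3 by methyl in place of hydrogen on an oxygen on an aromatic ring. Going by the values given here, no measured step bears on that change, so the expectation for compound 4 is no step beyond the scatter, no change at the digits printed from compound 3 to compound 4 (within the scatter). Compound 4 is therefore estimated at 100 mg/kg, with a range from 50 mg/kg to 200 mg/kg.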

Compound 4, dose for half-maximal effect: 30 mg/kg
Beside the measured number, compound 4's estimate is 3.3-fold (0.52 log units) above it; the whole stated range lies above it.
By their numbers in this assay, from the lowest: compound 4; then compounds 2 and 3 (each within the scatter of the next); then compound 1.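

In this assay hydroxy to methoxy on the aromatic ring gives a 3.3-fold lower number from compound 3 to compound 4 (0.52 log units; beyond the scatter) and so shows that this oxygen is not a silent place: one added methyl moves the number beyond the scatter, which the earlier step on the carbonyl carbon could not reveal. Nothing at hand accounts for this step. Going by these compounds, whether ethoxy, a longer chain on that oxygen or an amine in its place would move the number further remains open, as does whether the step holds with 4-chlorophenyl or phenoxymethyl on the carbonyl carbon.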